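Sulfonamide aryl exchange from compound 2 to compound 4

The source may report more compounds than this note shows. Statements on the series, on what has been measured and on what is new or still open speak of the compounds shown alone.

Compound 2 `Cc1cccc(S(=O)(=O)Nc2ccc3oc(-c4ccccc4)nc3c2)c1` stands only at a limit in an assay on cells for inhibition of HSP60/HSP10 (Homo sapiens), with a stated time of 60 min; a higher number here means a weaker inhibitor, a lower number a stronger inhibitor: it gives > 100000 nM, a limit of the assay and not a number. Compound 1 `Cc1ccccc1S(=O)(=O)Nc1ccc(-c2nc3ccccc3o2)cc1` gives 85000 nM in this assay. Compound 3 `CS(=O)(=O)Nc1ccc(-c2nc3ccccc3o2)cc1` likewise reaches only a limit in this assay, > 100000 nM. For the measured compounds named here, the one measured step, an at least 1.1-fold higher number from compound 1 to compound 3 (0.07 log units; that floor lies within the scatter), runs from a number into a limit and so gives a floor only; the limit of > 100000 nM in this assay, at which 2 of the 3 values shown sit, marks the ceiling at which most of the series sits. Compound 4 `COc1ccccc1S(=O)(=O)Nc1ccc2oc(-c3ccccc3)nc2c1` differs from compound 2 in one place: 2-methoxyphenyl in place of 3-methylphenyl on a sulfonyl sulfur. Going by the values given here, no measured step exchanges one aryl on the sulfonyl sulfur for another aryl, so the change to a 2-methoxyphenyl has no direct precedent here, and the step from compound 1 to compound 3 is the nearest comparison. With compound 2 already at a limit, the expected step that the limit leaves unreadable from compound 2 to compound 4 is none beyond the scatter, and a limit is the likelier read-out. For compound 4 the estimate in this assay is 150000 nM, within 60000 nM to 400000 nM.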

Compound 4, half-maximal inhibitory concentration: > 100000 nM
Compound 4: no number, only a limit; the forecaster's own chance of this, stated with the estimate: 70%; the middle value lies beyond the limit too.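

Compound 2 and compound 4 both stand at a limit of the assay and not at a number, so the step between them cannot be read. The compounds shown leave open what size of change, if any, this aryl exchange on the sulfonyl sulfur brings, and in which direction.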